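The compounds below may be only part of what the source reports. "The series", "measured", "known", "first", "only" and "open" are said of these compounds alone.

Measured so far:
- compound 1, `CCCCCCCCCCCC(=O)OC[C@H](CSC[C@@H](N)C(=O)N[C@@H](C)CO)OC(=O)CCCCCCCCCCC`: 1560 nM
- compound 2, `CCCCCCCCCCCC(=O)OC[C@H](CSC[C@@H](N)C(=O)NC(C)c1ccc(O)cc1)OC(=O)CCCCCCCCCCC`: 2890 nM

In an assay on HEK293 cells for agonist activity at Toll-like receptor 2 (Homo sapiens) (on this read-out lower numbers stand for an effect already at smaller amounts and higher numbers for an effect only at larger amounts of compound), compound 2 gives 2890 nM. On the two numbers at hand, compound 2 stands next to compound 1, whose value is 1560 nM; the step of a 1.9-fold higher number from compound 1 to compound 2 (0.27 log units; within the scatter) shows that the two cannot be told apart with this kind of measurement.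

Compound 3, `CCCCCCCCCCCC(=O)OC[C@H](CSC[C@@H](N)C(=O)NCCCN)OC(=O)CCCCCCCCCCC`, has not been measured. It differs from compound 2 in one place: 3-aminopropyl in place of 1-(4-hydroxyphenyl)ethyl on an amide-type nitrogen. The group that changes hangs on the amide-type nitrogen of the shared core, whose other neighbour is the carbonyl carbon, and the long-chain ester part of the molecule stays the same.

Among the compounds with values here, only one measured step touches this position, a 1.9-fold higher number from compound 1 to compound 2 (0.27 log units; within the scatter), and it swapped one small group for a larger, ring-bearing one without moving the number beyond the scatter. That single comparison suggests the amide substituent matters little here, so no step beyond the scatter is expected for a 1.4-fold lower number from compound 2 to compound 3 (0.16 log units; within the scatter); a drift back toward the number of compound 1 is possible but not required. Compound 3 is therefore estimated at 2000 nM, with a range from 700 nM to 6000 nM.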

Compound 3, half-maximal effective concentration: 1960 nM
Compound 3: middle estimate off by 1.0-fold (0.01 log units), on the high side; the range from low to high includes it.
By their numbers in this assay, from the lowest: compounds 1, 3 and 2 (each within the scatter of the next).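

In this assay the exchange of 1-(4-hydroxyphenyl)ethyl, with 9 heavy atoms and one aromatic ring, for 3-aminopropyl, with 4 heavy atoms and no ring, gives a 1.5-fold lower number from compound 2 to compound 3 (0.17 log units; within the scatter) and does not separate the two compounds. Replacing 1-(hydroxymethyl)ethyl by the same 3-aminopropyl gives a 1.3-fold higher number from compound 1 to compound 3 (0.10 log units; within the scatter) as well, so three groups on the amide-type nitrogen that differ in size, in having a ring or not, and in carrying oxygen or nitrogen all lie within the scatter of one another. Nothing measured here offers a reason for this flat picture.

From the compounds shown here alone, all three compounds carry a hydroxyl or an amine in this group, so it stays open whether a carboxylic acid there, or a much longer carbon chain on the same nitrogen, would move the number beyond the scatter. The long-chain ester part is also identical throughout, so this picture holds for these three compounds only and says nothing about a shorter ester chain.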